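A few compounds are considered here, and "the series" means these few. Any claim that something is new, unique, unknown or untested is made for them only; others in the source may bear on it.

Working notes on the series, read throughout in a functional assay on HT-29 cells (Homo sapiens) for antiproliferative activity, read by MTT assay, with a stated time of 24 h (a lower number here means a stronger inhibitor, a higher number a weaker inhibitor), as the only measure. Compound 1 `COc1cc(OC)c(OC)cc1/C=C/C(=O)c1ccc(OC)c2c1OC(C)(C)C=C2` gives > 10000 nM as a limit of the assay, not a number. Compound 2 `COc1ccc(C(=O)/C=C/c2cccc(F)c2)c2c1C=CC(C)(C)O2` gives > 10000 nM which is likewise only a limit. Its place in the series is thus the limit of > 10000 nM in this assay, at which 2 of the 3 values shown sit, and no number can be given for it. Among the measured compounds shown here, compound 3 `COc1ccc(C(=O)/C=C/c2ccc(N3CCCC3)cc2)c2c1C=CC(C)(C)O2` gives 8360 nM as the one true number so far.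

Compound 4 `COc1ccc(/C=C/C(=O)c2ccc(OC)c3c2OC(C)(C)C=C3)cn1` departs from compound 2 through 6-methoxypyridin-3-yl in place of 3-fluorophenyl on a double-bonded chain carbon bound to a double-bonded chain carbon with 6-methoxypyridin-3-yl in place of 3-fluorophenyl on a double-bonded chain carbon bound to a double-bonded chain carbon. For the measured compounds named here, no measured pair shows what such a replacement does. The expected move a step that the limit leaves unreadable from compound 2 to compound 4 is estimated to stay within the usual scatter, with no firm direction. For compound 4 the estimated value is 12000 nM within an expected range of 5000 nM to 30000 nM and a reading at the limit is also expected to be likely.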

Compound 4, half-maximal inhibitory concentration: > 10000 nM
Compound 4: no number, only a limit (the forecaster's own chance of this, stated with the estimate: 65%); the middle value lies beyond the limit too.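

Compound 2 and compound 4 each stand only as a limit of the assay, not a number, so no step can be read between them: the limit of > 10000 nM in this assay, at which 3 of the 4 values shown sit.

The compounds shown leave open whether 6-methoxypyridin-3-yl in place of 3-fluorophenyl makes any difference at all.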